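This account rests on a few compounds, and the source may have more. Where it says the series, first, only, none or still open, it means among the compounds named here.

Compound 1 `Fc1cccc(F)c1Cc1cnc(Nc2ccc(-c3ccncc3)c(Cl)c2)o1` gives 9300 nM in an ADME assay on MT2 cells (Homo sapiens) for cytotoxicity, read by MTT assay (on this read-out higher numbers stand for lower toxicity in this test and lower numbers for higher toxicity in this test), the lowest number among the three measured compounds: compound 3 `Clc1cccc(Cl)c1Cc1nnc(Nc2ccc(COCc3ccncc3)cc2)o1` gives 81000 nM and compound 2 `COCc1ccc(Nc2nnc(Cc3c(Cl)cccc3Cl)o2)cc1` gives 100000 nM, both beyond the scatter from compound 1. Compound 4 `Fc1cccc(F)c1Cc1cnc(Nc2ccc(Oc3cccnc3)c(Cl)c2)o1` differs from compound 1 by (pyridin-3-yl)oxy in place of pyridin-4-yl on an aromatic carbon, the change sitting ortho to a chloro group. Among the compounds with values here, the only measured step, a 1.2-fold lower number from compound 2 to compound 3 (0.09 log units; within the scatter), concerns a pyridin-4-yl entering on a saturated chain carbon of a different core and was within the scatter; no step tests a pyridinyl or pyridinyloxy exchange on an aromatic carbon. No shift beyond the scatter is therefore expected, so the step of a 1.3-fold higher number from compound 1 to compound 4 (0.11 log units; within the scatter) is estimated as small. Compound 4 is expected to give about 12000 nM, within 4000 nM to 40000 nM.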

Compound 4, half-maximal cytotoxic concentration: 16000 nM
Compound 4: middle estimate off by 1.3-fold (0.12 log units), on the low side, within the range that was stated.
By their numbers in this assay, from the lowest: compounds 1 and 4 (each within the scatter of the next); then compounds 3 and 2 (each within the scatter of the next).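

At this position, ortho to a chloro group and para to a large group, (pyridin-3-yl)oxy in place of pyridin-4-yl gives a 1.7-fold higher number from compound 1 to compound 4 (0.24 log units; within the scatter) in this assay on the shared core. Within the data shown here, this is the first exchange on this aromatic carbon, and its step stays within the scatter. No available evidence accounts for this result. Among these compounds, the single step changes both the oxygen link and the pyridine attachment, so a (pyridin-4-yl)oxy group would be needed to separate them. As far as these compounds go, whether an amine or a carboxylic acid here would shift the read-out remains open.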